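Cytotoxicity notes: hydroxyl in place of trifluoromethyl on the chain

This account rests on a few compounds, and the source may have more. Where it says the series, first, only, none or still open, it means among the compounds named here.

For the measured compounds named here, compound 1 `O=c1n(Cc2cc3cnccc3n2CCCC(F)(F)F)c2cnccc2n1C1CC1` is one of three compounds measured in an ADME assay on HeLa cells (Homo sapiens) for cytotoxicity, read by ATP content, with a stated time of 3 days; a higher number here means that more compound is tolerated, a lower number that less compound is tolerated. In this assay compound 1 gives > 50000 nM, a limit of the assay rather than a number. Compound 2 `CC(C)(O)CCCn1c(Cn2c(=O)n(C3CC3)c3ccncc32)nc2nc(Cl)ccc21` also reaches only a limit, > 50000 nM. Compound 3 `O=c1n(Cc2cc3cc(Br)ccc3n2CCCCO)c2cnccc2n1C1CC1` likewise stops at a limit, > 50000 nM. Hence (the limit of > 50000 nM in this assay, at which 3 of the 3 values shown sit), compound 1 stands level with every other measured compound, and no step between measured compounds can be read. Compound 4 `O=c1n(Cc2cc3cnccc3n2CCCCO)c2cnccc2n1C1CC1` differs from compound 1 by hydroxymethyl in place of trifluoromethyl on a saturated chain carbon, three bonds along the chain from an aromatic nitrogen. Compound 3 carries the same 4-hydroxybutyl chain and gives only the limit > 50000 nM. No step beyond the scatter is expected, so compound 4 is expected to show a number no higher from compound 1 to compound 4 (the limit leaves the size open). Compound 4 is estimated at 50000 nM, between 20000 nM and 100000 nM, most likely again as a limit.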

Compound 4, half-maximal cytotoxic concentration: > 100000 nM
Compound 4: a limit, no number; the forecaster's own chance of this, stated with the estimate: 85%; middle value at least 2.0-fold (0.30 log units) from the limit.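

In this assay compound 4 gives > 100000 nM, a limit and not a number. For the compounds shown here, with compound 1 also at a limit, no step between compound 1 and compound 4 can be read. The compounds shown leave open at what concentration any of them turns cytotoxic.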